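A few compounds are considered here, and "the series" means these few. Any claim that something is new, unique, unknown or untested is made for them only; others in the source may bear on it.

Measured so far:
compound 1, `O=C(Nc1nc(-c2ccccc2)nc2c1nnn2Cc1ccccc1)c1ccccc1C(F)(F)F`, 550 nM
compound 2, `COc1ccccc1C(=O)Nc1nc(-c2ccccc2)nc2c1nnn2Cc1ccccc1`, 1520 nM
compound 3, `O=C(Nc1nc(-c2ccccc2)nc2c1nnn2Cc1ccccc1)c1ccc(Cl)cc1`, 108 nM

In an assay (strain Wistar) for displacement of a labelled ligand from adenosine receptor A1 (Rattus norvegicus), read by scintillation counting (on this read-out lower numbers stand for stronger inhibition and higher numbers for weaker inhibition), compound 3 stands lowest of the three numbers. Its nearest neighbour is compound 1 at 550 nM, and its furthest is compound 2 at 1520 nM. Compound 4, `O=C(Nc1nc(-c2ccccc2)nc2c1nnn2Cc1ccccc1)c1ccc([N+](=O)[O-])cc1`, differs from compound 3 in one place: nitro in place of chloro on an aromatic carbon, on an aromatic carbon of a six-membered aromatic ring of carbon only, para to a large group. For the measured compounds named here, no measured step swaps one group for another on that ring. The steps of a 5.1-fold lower number from compound 1 to compound 3 (0.71 log units; beyond the scatter) and a 14-fold lower number from compound 2 to compound 3 (1.15 log units; beyond the scatter) exchange the whole aryl group on the carbonyl carbon, and the step of a 2.8-fold higher number from compound 1 to compound 2 (0.44 log units; beyond the scatter) exchanges two groups on an aromatic carbon of a different ring; each of them was beyond the scatter, so a change on this ring can move the number, but none tells the direction for a nitro group. Compound 4 is therefore expected near compound 3, with a modest move towards a higher number more likely than a lower one; the step of a 1.9-fold higher number from compound 3 to compound 4 (0.27 log units; within the scatter) is the estimate. For compound 4 the expected value is 200 nM, within a range from 60 nM to 700 nM.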

Compound 4, inhibition constant: 24 nM
Compound 4: the middle estimate sits 8.3-fold (0.92 log units) above what was measured; measured number outside the range, below it.
By their numbers in this assay, from the lowest: compound 4; then compound 3; then compound 1; then compound 2.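

In this assay, for the compounds shown here, the step (a 4.5-fold lower number from compound 3 to compound 4 (0.65 log units; beyond the scatter)) is the first exchange of one group for another on this ring, and it shows that the group on this aromatic carbon, para to a large group, can by itself move the number beyond the scatter, here towards a lower number with nitro. The exchanges of the whole aryl group on the carbonyl carbon (a 23-fold lower number from compound 1 to compound 4 (1.36 log units; beyond the scatter); a 63-fold lower number from compound 2 to compound 4 (1.80 log units; beyond the scatter)) place the 4-nitrophenyl amide lowest among the four compounds shown. No supporting information available here accounts for the gain from nitro over chloro.

Going by these compounds, what remains open is whether an amine, a carboxylic acid or a nitrile on this same carbon would follow nitro or chloro. On these data alone, it is also open whether nitro would give a similar step with a different group in place of the benzyl on the shared core.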